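The source may hold more compounds than are shown below. What is called first, only, known or untested is meant among the compounds shown, and "the series" means these compounds.

Series in a functional assay on PC-3 cells (Homo sapiens) for cytotoxicity, read by MTT assay, with a stated time of 96 h; on this read-out higher numbers stand for weaker inhibition and lower numbers for stronger inhibition:
- Compound 1 `CC[C@H](NC)C(=O)N[C@@H]1C(=O)N2[C@@H](CC[C@@H]1CN)CC[C@H]2C(=O)NC(c1ccccc1)c1ccccc1`: 51700 nM
- Compound 2 `CC[C@H](N)C(=O)N[C@@H]1C(=O)N2[C@@H](CC[C@@H]1CCO)CC[C@H]2C(=O)NC(c1ccccc1)c1ccccc1`: > 100000 nM, a limit
- Compound 3 `CC[C@H](N)C(=O)N[C@@H]1C(=O)N2[C@@H](CC[C@@H]1CCNC(=O)NCc1ccccc1)CC[C@H]2C(=O)NC(c1ccccc1)c1ccccc1`: > 100000 nM, a limit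

Within the data shown here, compound 1 holds the only number. The other two results are limits: the limit of > 100000 nM in this assay, at which 2 of the 3 values shown sit.

The compound to be measured next is compound 4 `CCNCC[C@H]1CC[C@H]2CC[C@@H](C(=O)NC(c3ccccc3)c3ccccc3)N2C(=O)[C@H]1NC(=O)[C@H](CC)NC`. It differs from compound 1 by (ethylamino)methyl in place of amino on a saturated chain carbon bound to a saturated ring carbon, with (ethylamino)methyl in place of amino on a saturated chain carbon bound to a saturated ring carbon. The same difference reads as aminomethyl to 2-(ethylamino)ethyl.

Among the measured compounds shown here, the only measured step is a step that the two limits leave unreadable from compound 2 to compound 3, so it gives no size to carry over to this change. The estimate therefore rests on compound 1 at 51700 nM, and no step beyond the scatter is expected in this assay, in either direction. A result reported only as a limit remains possible.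

The expected step is a 1.0-fold lower number from compound 1 to compound 4 (0.01 log units; within the scatter). For compound 4 the estimated value is 50000 nM, within an expected range of 18000 nM to 100000 nM.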

Compound 4, half-maximal inhibitory concentration: > 100000 nM
Compound 4: no number, only a limit (the forecaster's own chance of this, stated with the estimate: 30%); middle value at least 2.0-fold (0.30 log units) away from the limit.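

In this assay, going from aminomethyl to 2-(ethylamino)ethyl on the core of compound 1 gives a step with only a floor: an at least 1.9-fold higher number from compound 1 to compound 4 (0.28 log units; that floor lies within the scatter). That floor does not establish a loss of activity at this position, and the true size of the step cannot be read. Compound 4 gives a limit and not a number, which leaves compound 1 as the only compound with a measured value: the limit of > 100000 nM in this assay, at which 3 of the 4 values shown sit.

In compound 4 the longer chain and the ethyl group on the nitrogen enter together, so the compounds shown do not tell their contributions apart. Going by these compounds, a simple 2-aminoethyl chain at this position on the same core would separate the two, and whether any such amine gives a number in this assay remains open.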